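The compounds below may be only part of what the source reports. "The series", "measured", "known", "first", "only" and "open" are said of these compounds alone.

Compound 1 `CCCC(=O)Nc1cccc(S(=O)(=O)Oc2ccccc2C(C)C)c1` and compound 2 `CCCCCC(=O)Nc1cccc(S(=O)(=O)Oc2ccccc2C(C)C)c1` share one core; compound 3 `CCCC(=O)Nc1ccc(S(=O)(=O)Oc2ccccc2C(C)C)cc1` and compound 4 `CCCCCC(=O)Nc1ccc(S(=O)(=O)Oc2ccccc2C(C)C)cc1` share another, and the difference between the two cores is not broken down here. In a functional assay on M21 cells (Homo sapiens) for antiproliferative activity, read by sulforhodamine B assay, with a stated time of 48 h (on this read-out higher numbers stand for weaker inhibition and lower numbers for stronger inhibition), compound 1 gives 20000 nM, and compound 2 gives 11000 nM. The change from compound 1 to compound 2 is ethyl in place of hydrogen on a saturated chain carbon, three bonds along the chain from a carbonyl carbon; it gave a 1.8-fold lower number from compound 1 to compound 2 (0.26 log units; within the scatter). In this assay compound 3 gives 6100 nM; its gap to compound 2 is within the scatter, while its gap to compound 1 lies beyond it. Compound 4 carries the same change on the core of compound 3: ethyl in place of hydrogen on a saturated chain carbon, three bonds along the chain from a carbonyl carbon, a change seen once before in the series. Resting on that single earlier instance, the step expected in this assay is a 1.7-fold lower number from compound 3 to compound 4 (0.24 log units; within the scatter), about as small as the step before it, which stayed within the scatter. Compound 4 is therefore estimated at 3500 nM in this assay, with a range from 1500 nM to 8000 nM.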

Compound 4, half-maximal inhibitory concentration: 6700 nM
The estimate for compound 4 lay 1.9-fold (0.28 log units) below the measured number, and the stated range covers the measured number.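

In this assay, ethyl in place of hydrogen on the saturated chain carbon, three bonds along the chain from the carbonyl carbon, gave a 1.1-fold higher number from compound 3 to compound 4 (0.04 log units; within the scatter) on the core of compound 3. Set beside the earlier step, the result gives no sign that the outcome of this change depends on the core: the same change on two cores in this assay, a 1.8-fold lower number (0.26 log units; within the scatter) from compound 1 to compound 2 and a 1.1-fold higher number (0.04 log units; within the scatter) from compound 3 to compound 4, 2.0-fold (0.30 log units) apart, within the scatter of two such steps

Within these two pairs, the change can therefore be carried from one core to the other with no detectable difference, and on both cores it stays too small to read as a real effect. This does not show that the two steps are identical, that the change has any effect on either core, or that the agreement would extend to a third core.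

The compounds shown leave open whether a longer chain, a branched chain or a chain ending in an amine or a carboxylic acid would move the number beyond the scatter on either core. They also leave open whether such a group would behave alike on the two cores.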